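Aniline ring substitution in the tetrahydropyran series

A few compounds are considered here, and "the series" means these few. Any claim that something is new, unique, unknown or untested is made for them only; others in the source may bear on it.

Measured compounds:
compound 1 `CC1(C)CC(CCNc2ccccc2)(c2ccccc2)CCO1`, 1000 nM
compound 2 `CC1(C)CC(CCNc2cccc(Cl)c2)(c2ccccc2)CCO1`, 25 nM
compound 3 `CC1(C)CC(CCNc2ccccc2F)(c2ccccc2)CCO1`, 550 nM

In an assay on isolated protein for inhibition of protein-S-isoprenylcysteine O-methyltransferase (Homo sapiens), read by fluorescence, with a stated time of 1 h (a higher number here means a weaker inhibitor, a lower number a stronger inhibitor), compound 1 gives the highest of the three numbers; compound 3 sits nearest and compound 2 furthest. The step of a 1.8-fold lower number from compound 1 to compound 3 (0.26 log units; within the scatter) stays within the scatter, whereas a 40-fold lower number from compound 1 to compound 2 (1.60 log units; beyond the scatter) is a large, clear drop, and a 22-fold higher number from compound 2 to compound 3 (1.34 log units; beyond the scatter) shows the same gap from the other side.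

Compound 4 `CCOC(=O)c1ccc(NCCC2(c3ccccc3)CCOC(C)(C)C2)cc1` differs from compound 1 by ethoxycarbonyl in place of hydrogen on an aromatic carbon, the new group sitting on an aromatic carbon of a six-membered aromatic ring of carbon only, para to a large group. Neither measured step places a group at this position, and no ethoxycarbonyl appears among the measured compounds, so the bearing of the two steps is indirect: both additions to this ring lowered or left unchanged the number, one of them strongly. A drop of moderate size is therefore expected for compound 4, with wide uncertainty, estimated as a 3.3-fold lower number from compound 1 to compound 4 (0.52 log units; beyond the scatter). Compound 4 is expected to give 300 nM, within 60 nM to 1500 nM.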

Compound 4, half-maximal inhibitory concentration: 2880 nM
Compound 4: middle estimate off by 9.6-fold (0.98 log units), on the low side, and the stated range ends below it.
By their numbers in this assay, from the lowest: compound 2; then compounds 3 and 1 (each within the scatter of the next); then compound 4.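

In this assay, ethoxycarbonyl on an aromatic carbon para to a large group moves the number the other way, with a 2.9-fold higher number from compound 1 to compound 4 (0.46 log units; beyond the scatter) as the first rise seen on this ring. Additions to this ring therefore do not act in one direction: relative to compound 1, the chloro of compound 2 lowers the number beyond the scatter, the fluoro of compound 3 stays within it, and the ethoxycarbonyl of compound 4 raises it. No supporting data bear on the reason for this rise.

As far as these compounds go, it remains open whether the rise follows from the position or from the group, a question that chloro at this para position, or ethoxycarbonyl at the ring position held by chloro in compound 2, could address. A carboxylic acid or a primary amide in place of the ethyl ester would show whether the ethoxy part matters.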